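Nitro substitution on the arylhydrazone of compound 2

The compounds below may be only part of what the source reports. "The series", "measured", "known", "first", "only" and "open" are said of these compounds alone.

Within the data shown here, compound 1 `Cc1ccc2[nH]c(=O)c(/C=N/c3ccc(O)cc3)cc2c1` is the only member of the series with a number: in a functional assay, read by spectrophotometry, with a stated time of 5 min (a lower number here means a stronger inhibitor, a higher number a weaker inhibitor), compound 1 gives 235000 nM. Among the measured compounds shown here, compound 2 `Cc1ccc2[nH]c(=O)c(/C=N/Nc3ccc([N+](=O)[O-])cc3)cc2c1`, which carries a hydrazone linker to a nitro-bearing ring, is reported in this assay only as "not active" (no number reported), so no number stands for compound 2 and no step from compound 1 to compound 2 can be sized. Compound 3 `Cc1ccc2[nH]c(=O)c(/C=N/Nc3ccc([N+](=O)[O-])cc3[N+](=O)[O-])cc2c1` is still to be measured. The change from compound 2 to compound 3 is nitro in place of hydrogen on an aromatic carbon, in words a nitro in place of hydrogen on an aromatic carbon. For the measured compounds named here, no step between measured compounds exists to guide the size of this change in this assay; nothing in the two values shown points to a gain beyond the scatter, and the starting point is itself without a number. Compound 3 is therefore expected to sit near 300000 nM in this assay, within 80000 nM to 1500000 nM, with a good chance that again no number is obtained.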

Compound 3, half-maximal inhibitory concentration: "not active" (no number reported)
For compound 3 the study gives words and no number; no gap can be computed for the estimate.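

In this assay, among these compounds, compound 2 and compound 3 both stand without a number, so no step between them can be read. No available information explains this result. As far as these compounds go, whether a nitro in place of hydrogen on an aromatic carbon changes inhibition in this assay stays open.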